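Replacing the acid-bearing ring of an allosteric modulator

This account rests on a few compounds, and the source may have more. Where it says the series, first, only, none or still open, it means among the compounds named here.

Measured compounds:
Compound 1, `Cc1c(OC[C@@H](C)COc2ccc(Cl)c(C(=O)O)c2)ccc(C(=O)CC(C)(C)C)c1O`: 377 nM
Compound 2, `Cc1c(OC[C@@H](C)COc2ccc(C(=O)O)c(F)c2)ccc(C(=O)CC(C)(C)C)c1O`: 261 nM

The study measures two compounds in an assay for positive allosteric modulation of metabotropic glutamate receptor 2 (Rattus norvegicus); a higher number here means that more compound is needed for the effect, a lower number that less compound is needed. Compound 1 has the structure `Cc1c(OC[C@@H](C)COc2ccc(Cl)c(C(=O)O)c2)ccc(C(=O)CC(C)(C)C)c1O` and gives 377 nM in this assay. Compound 2, `Cc1c(OC[C@@H](C)COc2ccc(C(=O)O)c(F)c2)ccc(C(=O)CC(C)(C)C)c1O`, gives 261 nM. For the measured compounds named here, the only measured step, a 1.4-fold lower number from compound 1 to compound 2 (0.16 log units; within the scatter), leaves compound 2 within the scatter of compound 1, so neither can be called the stronger of the two.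

Compound 3 has the structure `COc1ccccc1OC[C@H](C)COc1ccc(C(=O)CC(C)(C)C)c(O)c1C`. It differs from compound 2 in one place: 2-methoxyphenyl in place of 4-carboxy-3-fluorophenyl on an oxygen on a saturated carbon. The measured step bears on this only indirectly, since it exchanged one carboxylic acid-bearing ring for another, whereas here the carboxylic acid leaves altogether and a methoxy group enters. Going by the values given here, no measured pair shows what the loss of the carboxylic acid does. The expectation is therefore cautious: a moderate shift toward a higher number, with a wide range. Compound 3 is estimated at 550 nM in this assay, between 150 nM and 3000 nM, a change of a 2.1-fold higher number from compound 2 to compound 3 (0.32 log units; beyond the scatter) from compound 2.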

Compound 3, half-maximal effective concentration: "not active" (no number reported)
For compound 3 the study gives words and no number, and the estimate cannot be compared.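

In this assay, for the compounds shown here, compound 3 is reported only as "not active", without a number, so no step from compound 2 to compound 3 can be read. The compounds shown leave open whether the missing carboxylic acid or the entering methoxy group accounts for this result. Nothing further shown here explains it.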